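The source may hold more compounds than are shown below. What is called first, only, known or untested is meant among the compounds shown, and "the series" means these compounds.

Measured compounds:
- compound 1, `ClCc1ccccc1Cn1cnc2ncnc(Cl)c21`: 3230 nM
- compound 2, `ClCc1ccc(Cn2cnc3c(Cl)nc(Cl)nc32)cc1`: 19500 nM

In a functional assay on UO-31 cells (Homo sapiens) for cytotoxicity, read by sulforhodamine B assay, with a stated time of 48 h (a lower number here means a stronger inhibitor of growth, a higher number a weaker inhibitor of growth), compound 1 holds the lowest of the two numbers; compound 2 gives the higher number, and the gap between the two lies beyond the scatter. The two differ in more than one place, so the values alone do not separate the changes. Compound 3, `ClCc1ccccc1Cn1cnc2nc(Cl)nc(Cl)c21`, differs from compound 1 only in chloro in place of hydrogen on an aromatic carbon. Among the compounds with values here, no single-change step on this point has been measured in this assay, so the direction is uncertain; a moderate weakening is expected, guided by the higher number compound 2 gives with 19500 nM. The expected step from compound 1 to compound 3 is a 1.7-fold higher number from compound 1 to compound 3 (0.23 log units; within the scatter). For compound 3 the estimate in this assay is 5500 nM, within 2000 nM to 16000 nM.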

Compound 3, concentration for 50% growth inhibition: 1730 nM
Compound 3: the middle estimate sits 3.2-fold (0.50 log units) above what was measured, outside the stated range (below it).
By their numbers in this assay, from the lowest: compounds 3 and 1 (each within the scatter of the next); then compound 2.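

In this assay, within the data shown here, chloro in place of hydrogen on an aromatic carbon between two ring nitrogen atoms gives a 1.9-fold lower number from compound 1 to compound 3 (0.27 log units; within the scatter) and so provides the first single-change reading at this position. Compound 1 and compound 3 cannot be told apart here, so this position carries a chloro group with no effect separable from the scatter. No available measurement bears on a reason for this result.

On these data alone, whether an amine or a methoxy group at this position would behave like chloro remains open. So does the effect of replacing the chloromethyl group.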